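The compounds below may be only part of what the source reports. "The series", "measured", "known", "first", "only" and "open" are said of these compounds alone.

Measured in an ADME assay on BE(2)-C cells (Homo sapiens) for cytotoxicity, read by MTT assay, with a stated time of 20 h; a higher number here means that more compound is tolerated, a lower number that less compound is tolerated:

Compound 1 `Cn1ccc(CNC(=O)C2CCN(C(=O)c3cc4ccccc4n3Cc3ccc(Cl)cc3)CC2)n1`: > 100000 nM, a limit
Compound 2 `O=C(NCCCc1ccncc1)C1CCN(C(=O)c2cc3ccccc3n2Cc2ccc(Cl)cc2)CC1`: 71500 nM
Compound 3 `CN(Cc1ccccc1)C(=O)C1CCN(C(=O)c2cc3ccccc3n2Cc2ccc([N+](=O)[O-])cc2)CC1`: > 100000 nM, a limit

In this assay compound 3 gives only a limit, > 100000 nM. Its result thus belongs to the limit of > 100000 nM in this assay, at which 2 of the 3 values shown sit. Compound 4 `CN(Cc1ccccc1)C(=O)C1CCN(C(=O)c2cc3ccccc3n2Cc2ccccc2)CC1` has hydrogen in place of nitro on an aromatic carbon, para to a large group (hydrogen in place of nitro on an aromatic carbon). Going by the values given here, no measured step covers this change. The only one, an at least 1.3-fold lower number from compound 1 to compound 2 (0.14 log units; that floor lies within the scatter), lies elsewhere in the molecule, and its floor is within the scatter. It offers weak guidance at best, but compound 2 does show that a number can be obtained in this series, at 71500 nM. No clear shift is therefore expected from removing the nitro group, and compound 4 may well reach the limit too. The expected change is an at least 1.1-fold lower number from compound 3 to compound 4 (0.04 log units; that floor lies within the scatter), which is not expected to exceed the scatter. The estimated value for compound 4 is 90000 nM. Its expected range runs from 35000 nM to 200000 nM.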

Compound 4, half-maximal cytotoxic concentration: 64800 nM
Estimate against measurement, compound 4: 1.4-fold (0.14 log units) above; the range from low to high includes it.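

For this position, this assay now gives a first reading: the change from 4-nitrobenzyl to benzyl yields an at least 1.5-fold lower number from compound 3 to compound 4 (0.18 log units; that floor lies within the scatter) and shows that the unsubstituted benzyl compound gives a number rather than a limit. That floor does not show a shift beyond the usual scatter, so removing the nitro group cannot be said to alter tolerance in these cells. From the compounds shown here alone, the true size of the step stays unknown because one end of it is a limit: the limit of > 100000 nM in this assay, at which 2 of the 4 values shown sit.

The compounds shown leave open how an amine or a methoxy group on this same aromatic carbon, para to a large group, would read in this assay on this scaffold. They also leave open whether a chlorine here would give a number or a limit with the amide side of compound 4.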